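Hydrogen for phenyl on the amide nitrogen of compound 1

The compounds below may be only part of what the source reports. "The series", "measured", "known", "first", "only" and "open" are said of these compounds alone.

Compound 1 `O=C1COc2ccc(-c3cccc(NS(=O)(=O)c4ccc(F)cc4)c3)cc2N1c1ccccc1` carries a phenyl on the amide-type nitrogen of the shared core. In a functional assay on HeLa cells (Homo sapiens) for antiproliferative activity, read by MTT assay, with a stated time of 72 h (a higher number here means a weaker inhibitor, a lower number a stronger inhibitor), compound 1 gives 17700 nM. Compound 3 `Cc1ccc(N2C(=O)COc3ccc(-c4cnc(Cl)c(NS(=O)(=O)c5ccc(F)cc5)c4)cc32)cc1` gives 32300 nM, a number within the scatter of that of compound 1, so the two cannot be ordered. Compound 2 `COc1ncc(-c2ccc3c(c2)N(C2CCCCC2)C(=O)CO3)cc1NS(=O)(=O)c1ccc(F)cc1` differs from compound 1 at several places at once. In this assay compound 2 gives 6100 nM, a lower number than that of compound 1 and beyond the scatter. Compound 1 therefore stands second highest of the three numbers.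

Compound 4 `O=C1COc2ccc(-c3cccc(NS(=O)(=O)c4ccc(F)cc4)c3)cc2N1` is not yet measured. It differs from compound 1 in one place: hydrogen in place of phenyl on an amide-type nitrogen in a ring. Among the compounds with values here, no measured pair differs in only one place, so the size of such a step is not known from these data. The change is expected to shift the number only slightly, toward a weaker inhibitor, with a step from compound 1 to compound 4 of a 1.7-fold higher number from compound 1 to compound 4 (0.23 log units; within the scatter) that stays near the scatter. In this assay compound 4 is estimated at 30000 nM, with a range from 10000 nM to 90000 nM.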

Compound 4, half-maximal inhibitory concentration: > 40000 nM
Compound 4 was reported as a limit; the forecaster's own chance of this, stated with the estimate: 15%; at least 1.3-fold (0.12 log units) between middle value and limit.
By their numbers in this assay, from the lowest: compound 2; then compounds 1 and 3 (each within the scatter of the next). At a limit, above all of these: compound 4.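

The single-place change at this position has a readable effect: with the rest of compound 1 held fixed, hydrogen in place of phenyl on the amide-type nitrogen gives, in this assay, an at least 2.2-fold higher number from compound 1 to compound 4 (0.35 log units; beyond the scatter). The position is therefore not indifferent to what it carries, and the phenyl is linked to the stronger inhibition in this pair. Compound 4 stands at > 40000 nM, which is a limit and not a number, so the step has a lower bound only, and that reading rests on the limit: the limit of > 40000 nM in this assay, at which 1 of the 4 values shown sits.

Going by these compounds, whether a phenyl is needed here, or whether a small alkyl such as methyl, a longer chain or a chain ending in an amine would serve on this nitrogen, stays open. Compounds 2 and 3 differ from compound 1 at more than this place and cannot settle it.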